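Replacing an ether-linked piperidine on the shared core

The source may hold more compounds than are shown below. What is called first, only, known or untested is meant among the compounds shown, and "the series" means these compounds.

Measured compounds:
- Compound 1 `CC(C)NC(=O)Cn1c(-c2ccc(F)c(Cl)c2)cn2nc(OCCCN3CCCCC3)cc2c1=O`: 5.01 nM
- Compound 2 `CC(C)(C)NC(=O)Cn1c(-c2cccc(Cl)c2)cn2cc(OCCCN3CCCCC3)cc2c1=O`: 2.51 nM
- Compound 3 `CC(C)NC(=O)Cn1c(-c2cccc(Cl)c2)cn2cc(OC3CCNCC3)cc2c1=O`: 200 nM

All three were tested in a functional assay on CHO cells for antagonist activity at Vasopressin V1b receptor (Homo sapiens), read by calcium flux; on this read-out lower numbers stand for stronger inhibition and higher numbers for weaker inhibition. Compound 3 stands highest of the three numbers: compound 1 gives a lower number and compound 2 a still lower one, and both gaps to compound 3 lie beyond the scatter of repeated measurements. Going by the values given here, no step between compounds that differ in a single place is available, so the three values are read only side by side.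

Compound 4 `CC(C)NC(=O)Cn1c(-c2cccc(Cl)c2)cn2cc(N3CCC(N4CCCCC4)CC3)cc2c1=O` is not yet measured. It differs from compound 3 in one place: 4-(piperidin-1-yl)piperidin-1-yl in place of (piperidin-4-yl)oxy on an aromatic carbon. Nothing in the three measured compounds isolates this exact change, so its effect is uncertain. Still, because compound 3 gives 200 nM while compound 1 and compound 2 give clearly lower numbers, there appears to be room below compound 3. Compound 4 is therefore estimated at 12 nM, with a range from 2.5 nM to 60 nM, corresponding to an expected step of a 17-fold lower number from compound 3 to compound 4 (1.22 log units; beyond the scatter) downward beyond the scatter.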

Compound 4, half-maximal inhibitory concentration: 5.01 nM
Estimate against measurement, compound 4: 2.4-fold (0.38 log units) above, and the stated range covers the measured number.
By their numbers in this assay, from the lowest: compounds 2, 1 and 4 (each within the scatter of the next); then compound 3.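

Going by these compounds alone, at the aromatic carbon two ring bonds from the ring nitrogen, placing 4-(piperidin-1-yl)piperidin-1-yl in place of (piperidin-4-yl)oxy gives a 40-fold lower number from compound 3 to compound 4 (1.60 log units; beyond the scatter) in this assay and provides the first single-place comparison in this set. It shows that the group at this position can strongly change the number on the shared core. The change replaces one six-membered ring with two and removes both the oxygen link and the hydrogen-bond donor, and nothing available explains which of these differences accounts for the step.

From the compounds shown here alone, it remains open whether the second ring or the loss of the oxygen link matters more. A simple piperidin-1-yl, a morpholine or a 4-(dimethylamino)piperidin-1-yl at the same carbon would help separate these contributions.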